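Ester aryl substituent change on the shared core

The source may hold more compounds than are shown below. What is called first, only, known or untested is meant among the compounds shown, and "the series" means these compounds.

Compound 1 `COc1cccc(C(=O)Oc2cc3c(cc2C)[C@@H](C(C)C)CC=C3C)c1` bears a methoxy on a six-membered aromatic ring of carbon only, and in a functional assay on U-251 cells (Homo sapiens) for antiproliferative activity, read by sulforhodamine B assay, with a stated time of 48 h, tested at 50 uM (a lower number here means less inhibition, a higher number more inhibition at the concentration tested (going by the name of the read-out)), compound 1 is reported as "not active" (no number reported), with no number given. Compound 2 `CC1=CC[C@H](C(C)C)c2cc(C)c(OC(=O)c3ccc(Cl)cc3)cc21` gives 25.6% in this assay. Compound 3 `CC1=CC[C@H](C(C)C)c2cc(C)c(OC(=O)c3cccc(C)c3)cc21` differs from compound 1 by methyl in place of methoxy on an aromatic carbon. Among the measured compounds shown here, no step between measured compounds covers this change, so its size is unknown; compound 1 has only a reported verdict and no number, so there is no number from which a shift for compound 3 could be counted. Compound 3 is estimated at 12% in this assay, with a range of 0% to 30%.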

Compound 3, a percentage reported as inhibition, at one concentration (the size of the read-out at that concentration, not a potency): 16.8%
Estimate against measurement, compound 3: 4.8 percentage points below, and the stated range covers the measured number.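

With the ester aryl group changed, 3-methylphenyl in place of 4-chlorophenyl gives a number 8.8 percentage points lower from compound 2 to compound 3 (within the scatter) in this assay, so this change does not separate the two esters. Compound 3 gives 16.8%, while compound 1 stands as "not active" (no number reported); the step from methoxy to methyl cannot be read as a size. No available measurement accounts for either result.

Still open, as far as these compounds go, is how an amine or a carboxylic acid in the same place on the aromatic ring would read in this assay. From the compounds shown here alone, an ethyl group there is equally open.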